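A trifluorophenyl swap on the weakest of three compounds

The compounds below may be only part of what the source reports. "The series", "measured", "known", "first", "only" and "open" are said of these compounds alone.

Compound 1 `OC[C@H]1O[C@@H](n2cnc3c(NCc4ccc(Cl)cc4)ncnc32)[C@H](O)[C@@H]1O`, compound 2 `OC[C@H]1O[C@@H](n2cnc3c(NCc4cccc(Br)c4)ncnc32)[C@H](O)[C@@H]1O` and compound 3 `OC[C@H]1O[C@@H](n2cnc3c(NCc4ccc(Cl)cc4Cl)ncnc32)[C@H](O)[C@@H]1O` share one core and differ only in the halogen-bearing phenyl group on a saturated chain carbon bound to a nitrogen on an aromatic ring. In a functional assay on CCRF-CEM cells (Homo sapiens) for antiproliferative activity, with a stated time of 72 h (on this read-out higher numbers stand for weaker inhibition and lower numbers for stronger inhibition), compound 1 gives 10200 nM, compound 2 gives 5000 nM and compound 3 gives 86700 nM. Compound 3 therefore has the highest number of the three, which makes it the weakest inhibitor so far.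

Compound 4 `OC[C@H]1O[C@@H](n2cnc3c(NCc4c(F)ccc(F)c4F)ncnc32)[C@H](O)[C@@H]1O` is the next to be measured. It carries 2,3,6-trifluorophenyl in place of 2,4-dichlorophenyl on a saturated chain carbon bound to a nitrogen on an aromatic ring. Among the measured compounds shown here, no measured compound contains fluorine, so the evidence is indirect. Adding a chloro group produced an 8.5-fold higher number from compound 1 to compound 3 (0.93 log units; beyond the scatter), and replacing 3-bromophenyl with 2,4-dichlorophenyl produced a 17-fold higher number from compound 2 to compound 3 (1.24 log units; beyond the scatter). The change between the two singly halogenated groups was much smaller, at a 2.0-fold lower number from compound 1 to compound 2 (0.31 log units; beyond the scatter).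

Only the 2,4-dichlorophenyl group has given a number this high, and that group leaves in this change. A modest move toward a lower number is therefore expected in this assay, although the fluorines make this uncertain. The expected change is a 4.3-fold lower number from compound 3 to compound 4 (0.64 log units; beyond the scatter). Compound 4 is estimated at 20000 nM, with an expected range of 5000 nM to 80000 nM.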

Compound 4, half-maximal inhibitory concentration: 90300 nM
Compound 4: middle estimate off by 4.5-fold (0.65 log units), on the low side, outside the stated range (above it).
By their numbers in this assay, from the lowest: compound 2; then compound 1; then compounds 3 and 4 (each within the scatter of the next).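

The swap of 2,4-dichlorophenyl for 2,3,6-trifluorophenyl gives a 1.0-fold higher number from compound 3 to compound 4 (0.02 log units; within the scatter), so in this assay these two groups cannot be told apart at this position on a saturated chain carbon bound to a nitrogen on an aromatic ring. The high number is therefore not unique to 2,4-dichlorophenyl or to chlorine: a group with only fluorine on its ring also sits far from the singly halogenated groups, with an 18-fold higher number from compound 2 to compound 4 (1.26 log units; beyond the scatter) and an 8.9-fold higher number from compound 1 to compound 4 (0.95 log units; beyond the scatter), and among these four compounds none goes against this split between the singly and the more heavily halogenated groups. Nothing measured here explains why the two groups give such similar numbers.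

The compounds shown leave open whether the split follows the number of halogens on the ring, where they sit, or something else about these groups. A plain phenyl group with no halogen, a phenyl group carrying a single fluoro, and one carrying a methoxy group or an amine would each help to separate these possibilities.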